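The compounds below may be only part of what the source reports. "The series", "measured", "known", "first", "only" and "open" are said of these compounds alone.

In an ADME assay on CHO-K1 cells (Cricetulus griseus) for cytotoxicity, read by MTT assay, with a stated time of 24 h (a higher number here means a weaker inhibitor, a lower number a stronger inhibitor), compound 1 (`CCCCCCCC/C=C\CCCCCCCC(=O)Nc1nnc(S[C@@H]2O[C@H](COC(C)=O)[C@H](OC(C)=O)[C@H](OC(C)=O)[C@H]2OC(C)=O)s1`) gives 26300 nM and compound 3 (`CCCCCCCC/C=C\CCCCCCCCCCCC(=O)Nc1nnc(S[C@@H]2O[C@H](COC(C)=O)[C@H](OC(C)=O)[C@H](OC(C)=O)[C@H]2OC(C)=O)s1`) gives 25200 nM. These two values lie within the usual scatter of each other, so compound 3 shares its place on the scale with compound 1. Compound 2 (`CCCCCC(=O)Nc1nnc(S[C@@H]2O[C@H](CO)[C@H](O)[C@H](O)[C@H]2O)s1`) is reported as "not active" (no number reported), which offers no number to compare. Compound 4 (`CCCCCCCCCCCCCCCC(=O)Nc1nnc(S[C@@H]2O[C@H](COC(C)=O)[C@H](OC(C)=O)[C@H](OC(C)=O)[C@H]2OC(C)=O)s1`) has butyl in place of dec-1-en-1-yl on a saturated chain carbon, ten or more bonds along the chain from a carbonyl carbon. The chains of compounds 1 and 3 differ, yet their values do not separate, so no step beyond the scatter is expected in this assay. The estimated step is a 1.0-fold lower number from compound 3 to compound 4 (0.00 log units; within the scatter). Compound 4 is expected at 25000 nM, with an estimated range from 12000 nM to 50000 nM.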

Compound 4, half-maximal inhibitory concentration: 90400 nM
For compound 4 the middle estimate is 3.6-fold (0.56 log units) below the measured one, outside the stated range (above it).
By their numbers in this assay, from the lowest: compounds 3 and 1 (each within the scatter of the next); then compound 4.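

In this assay, butyl in place of dec-1-en-1-yl, on a saturated chain carbon, gives a 3.6-fold higher number from compound 3 to compound 4 (0.55 log units; beyond the scatter), and octyl in place of dec-1-en-1-yl gives a 3.4-fold higher number from compound 1 to compound 4 (0.54 log units; beyond the scatter). Changing the far end of the chain can therefore move this number, which compound 1 and compound 3, within the scatter of each other, did not show. Nothing measured here explains the step. The double bond and the chain length change together in compound 4, so their shares remain unseparated. A longer saturated chain would help to tell them apart.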